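The compounds below may be only part of what the source reports. "The series", "measured", "known", "first", "only" and "open" are said of these compounds alone.

Working notes. For the measured compounds named here, compound 3 `CCc1ccccc1C(Nc1ccc(Cl)cc1Cl)C(=O)CCc1ccncc1` carries the only number in the set: in an assay on isolated protein for binding affinity to corticotropin-releasing factor receptor 1 (Homo sapiens) (a higher number here means a weaker inhibitor, a lower number a stronger inhibitor), compound 3 gives 330 nM. Compound 1 `Cc1ccc(NC(C(=O)CCc2cccnc2)c2ccccc2Br)c(Cl)c1` reaches only a limit in this assay, > 10000 nM. Compound 2 `Cc1ccc(NC(C(=O)CCc2ccc(F)cc2)c2ccccc2Br)c(Cl)c1` likewise sits at a limit in this assay, > 10000 nM. The step that the two limits leave unreadable from compound 1 to compound 2 therefore stays unreadable, because the limit of > 10000 nM in this assay, at which 2 of the 3 values shown sit, covers both ends of it, and it concerns a different place in any case. Compound 4 `Cc1cc(F)ccc1C(Nc1ccc(Cl)cc1Cl)C(=O)CCc1ccncc1` differs from compound 3 by 4-fluoro-2-methylphenyl in place of 2-ethylphenyl on a saturated chain carbon bound to a carbonyl carbon and a nitrogen on an aromatic ring. Going by the values given here, no measured step touches this place, so no size can be read from the series; compound 4 is expected to stay within the scatter of compound 3, an estimated 1.2-fold higher number from compound 3 to compound 4 (0.08 log units; within the scatter). The estimate for compound 4 in this assay is 400 nM, range 120 nM to 1500 nM.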

Compound 4, inhibition constant: 512 nM
Compound 4: the middle estimate sits 1.3-fold (0.11 log units) below what was measured; low and high end bracket the measured number.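

In this assay, for the compounds shown here, the first readable step at this position is 4-fluoro-2-methylphenyl in place of 2-ethylphenyl, on a saturated chain carbon bound to a carbonyl carbon and a nitrogen on an aromatic ring: a 1.6-fold higher number from compound 3 to compound 4 (0.19 log units; within the scatter). This place therefore accepts a fluorine-bearing aromatic ring of the same heavy-atom count with no change beyond the scatter. Nothing shown bears on a cause for this result.

Going by these compounds alone, the single step does not separate the 4-fluoro group from the exchange of ethyl for methyl. As far as these compounds go, what a cyclohexyl group or a carboxylic acid at this place would give remains open.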